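Chloro for methyl on the carboxyphenyl ring of compound 3

The source may report more compounds than this note shows. Statements on the series, on what has been measured and on what is new or still open speak of the compounds shown alone.

Compound 3 `Cc1cc(OCCCCOc2ccc(C(=O)CC3CCCC3)c(O)c2C)ccc1C(=O)O` gives 564 nM in an assay on HEK293 cells for positive allosteric modulation of metabotropic glutamate receptor 2 (Rattus norvegicus), read by thallium flux, with a stated time of 2.5 min (on this read-out higher numbers stand for an effect only at larger amounts of compound and lower numbers for an effect already at smaller amounts), the second highest of the three numbers at hand. Its nearest neighbour is compound 2 `Cc1c(OCCCCOc2ccc(C(=O)O)cc2)ccc(C(=O)CC2CCCC2)c1O` with 824 nM, a gap within the scatter; the furthest is compound 1 `Cc1c(OCCCCOc2ccc(C(=O)O)cc2Cl)ccc(C(=O)CC2CCCC2)c1O` with 237 nM, which shows a 2.4-fold higher number from compound 1 to compound 3 (0.38 log units; beyond the scatter).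

Compound 4 `Cc1c(OCCCCOc2ccc(C(=O)O)c(Cl)c2)ccc(C(=O)CC2CCCC2)c1O` differs from compound 3 in one place: chloro in place of methyl on an aromatic carbon.

Among the compounds with values here, two measured steps bear on this change, though neither reproduces it exactly. Removing a chloro, a 3.5-fold higher number from compound 1 to compound 2 (0.54 log units; beyond the scatter), was a modest loss, but that chloro sat in a 4-carboxy-2-chlorophenyl group, not ortho to a carboxy group as in compound 4. Adding a methyl, a 1.5-fold lower number from compound 2 to compound 3 (0.16 log units; within the scatter), stayed within the scatter. Taken together, chloro in place of methyl is therefore expected to move the number only modestly, with a lean toward a lower value on the strength of the chloro in compound 1, 237 nM.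

Compound 4 is thus estimated at 350 nM, with a range of 130 nM to 900 nM. The expected step from compound 3 is a 1.6-fold lower number from compound 3 to compound 4 (0.21 log units; within the scatter).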

Compound 4, half-maximal effective concentration: 510 nM
The estimate for compound 4 lay 1.5-fold (0.16 log units) below the measured number; measured number inside the range.
By their numbers in this assay, from the lowest: compound 1; then compounds 4, 3 and 2 (each within the scatter of the next).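

In this assay, placed ortho to a carboxy group, chloro and methyl cannot be told apart (a 1.1-fold lower number from compound 3 to compound 4 (0.04 log units; within the scatter)), and chloro at this position also cannot be told apart from hydrogen (a 1.6-fold lower number from compound 2 to compound 4 (0.21 log units; within the scatter)). The benefit of chloro seen earlier therefore does not follow the atom to every place on the carboxyphenyl ring: the 4-carboxy-2-chlorophenyl group of compound 1 stands apart, and the 4-carboxy-3-chlorophenyl group gives up part of that edge (a 2.2-fold higher number from compound 1 to compound 4 (0.33 log units; beyond the scatter)), so among these compounds the place of the chloro matters more than its presence. Nothing available here accounts for the difference between the two chloro placements.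

From the compounds shown here alone, what remains open is whether any other group ortho to a carboxy group, such as fluoro, methoxy or a nitrile, would separate from hydrogen there, or whether this position simply tolerates small changes. Going by these compounds, it is also open whether methyl or fluoro at the place the chloro holds in compound 1 would keep the edge that chloro gives there, and whether that edge survives a shorter or longer chain between the two oxygens.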